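Adding a cyclopropyl group to an unsubstituted nitrogen

This account rests on a few compounds, and the source may have more. Where it says the series, first, only, none or still open, it means among the compounds named here.

In a functional assay on K562 cells (Homo sapiens) for inhibition, read by trypan blue exclusion, with a stated time of 72 h (a lower number here means a stronger inhibitor, a higher number a weaker inhibitor), compound 2 `O=c1[nH]c2nc(Nc3ccc4[nH]ccc4c3)ncc2cc1S(=O)(=O)c1ccc(F)cc1F` gives 15000 nM as its value. That number lies within the scatter of compound 3 `Cn1c(=O)c(S(=O)(=O)c2ccc(F)cc2)cc2cnc(Nc3ccc4[nH]ncc4c3)nc21` with 10000 nM as its value, and well above compound 1 `CCCn1c(=O)c(S(=O)(=O)c2ccc(F)cc2F)cc2cnc(Nc3ccc4[nH]ccc4c3)nc21` with 1000 nM as its value.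

Compound 4 `O=c1c(S(=O)(=O)c2ccc(F)cc2F)cc2cnc(Nc3ccc4[nH]ccc4c3)nc2n1C1CC1` differs from compound 2 in one place, with cyclopropyl in place of hydrogen on an aromatic nitrogen. For the measured compounds named here, one measured step bears on this change, a 15-fold higher number from compound 1 to compound 2 (1.18 log units; beyond the scatter) with hydrogen in place of propyl on an aromatic nitrogen, and it is large. Compound 3 differs from compound 2 in more than one place, so it offers no clean comparison. Read in reverse, that single step points to a lower number when a carbon group fills the position, although whether cyclopropyl matches propyl is untested.

A large step toward a lower number is therefore expected in this assay for this change (a 13-fold lower number from compound 2 to compound 4 (1.10 log units; beyond the scatter)). Compound 4 is estimated at 1200 nM with 300 nM to 5000 nM as the expected range.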

Compound 4, half-maximal inhibitory concentration: 500 nM
Compound 4: middle estimate off by 2.4-fold (0.38 log units), on the high side; the range from low to high includes it.
By their numbers in this assay, from the lowest: compounds 4 and 1 (each within the scatter of the next); then compounds 3 and 2 (each within the scatter of the next).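

In this assay, cyclopropyl on the aromatic nitrogen gives a 30-fold lower number from compound 2 to compound 4 (1.48 log units; beyond the scatter), so a second carbon group, this one a three-membered ring, shows the same large effect that propyl showed, and the effect is not tied to a single group. Exchanging propyl for cyclopropyl gives a 2.0-fold lower number from compound 1 to compound 4 (0.30 log units; within the scatter), which means that the open chain and the ring cannot be told apart at this position in these cells. No measurement shown here explains why filling this nitrogen with carbon matters so much.

On these data alone, whether a longer chain such as hexyl would keep this level of inhibition remains open. So does the outcome for a chain ending in an amine or a carboxylic acid, which would place something other than plain carbon on this nitrogen.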